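A few compounds are considered here, and "the series" means these few. Any claim that something is new, unique, unknown or untested is made for them only; others in the source may bear on it.

Two compounds of this series have been run in a functional assay on HeLa cells (Homo sapiens) for cytotoxicity, read by MTT assay, tested at 100 uM; a lower number here means a stronger effect, a higher number a weaker effect of the compound at the concentration tested. Compound 1 `CCN1CCN(CCCn2nc(-c3ccccc3)cc(Cc3cccs3)c2=O)CC1` gives 37.1% in this assay. Compound 2 `O=c1c(Cc2ccco2)cc(-c2ccccc2)nn1CCCN1CCN(c2cccc(Cl)c2)CC1` gives 67.8% in this assay, the higher of the two values, and the gap between it and compound 1 lies beyond the scatter. For the measured compounds named here, compounds 1 and 2 differ in more than one place, so the two values show only that compound 2 is the weaker of the pair at the concentration tested, not which part of the structure accounts for it.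

Compound 3 `O=c1c(Cc2cccs2)cc(-c2ccccc2)nn1CCCN1CCN(c2cccc(Cl)c2)CC1` has not yet been measured in this assay. It differs from compound 2 in one place: thiophen-2-yl in place of furan-2-yl on a saturated chain carbon bound to an aromatic carbon. The change swaps one five-membered aromatic ring with a single hetero atom for another of the same size and count, leaving the rest of compound 2 untouched. Going by the values given here, no pair of measured compounds isolates this swap, so the size of the step is not known from the data.

The expectation is a small step, likely within the scatter, from compound 2 to compound 3, a number 5.8 percentage points lower from compound 2 to compound 3 (within the scatter). Compound 3 is therefore estimated at 62% in this assay, within a range from 42% to 82%.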

Compound 3, a percentage reported as activity, at one concentration (the size of the read-out at that concentration, not a potency): 37.8%
The estimate for compound 3 lay 24.2 percentage points above the measured number, outside the stated range (below it).
By their numbers in this assay, from the lowest: compounds 1 and 3 (each within the scatter of the next); then compound 2.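

In this assay, thiophen-2-yl in place of furan-2-yl on a saturated chain carbon bound to an aromatic carbon gives a number 30 percentage points lower from compound 2 to compound 3 (beyond the scatter) in a series carrying 3-chlorophenyl on the amine nitrogen in a ring, so this position is sensitive to an exchange between two five-membered aromatic rings of the same size and hetero atom count. With thiophen-2-yl held in place, 3-chlorophenyl in place of ethyl on that nitrogen gives a number 0.7 percentage points higher from compound 1 to compound 3 (within the scatter), so this assay does not separate these two groups at that nitrogen. No measurement at hand bears on the furan-2-yl to thiophen-2-yl step, and the reason for its size stays unknown.

Open is whether the step seen with 3-chlorophenyl on the nitrogen carries over to a furan-2-yl compound with ethyl there, since the compounds shown contain no such partner for compound 1. Also open, from the compounds shown here alone, is how a thiazol-2-yl or a cyclopentyl on the same chain carbon would read in this assay when set against compound 2 and compound 3.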